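This account rests on a few compounds, and the source may have more. Where it says the series, first, only, none or still open, it means among the compounds named here.

Among the compounds with values here, in an ADME assay on CCD-1095SK cells (Homo sapiens) for antiproliferative activity, read by crystal violet staining, with a stated time of 96 h (on this read-out higher numbers stand for an effect only at larger amounts of compound and lower numbers for an effect already at smaller amounts), compound 2 (`O[C@H]1[C@H](Oc2ccc3ccccc3c2)OCC[C@@H]1O`) gives 285 uM as the higher of the two numbers so far, and compound 1 (`O[C@@H]1[C@@H](O)[C@H](Oc2ccc3ccccc3c2)OC[C@H]1F`) gives 32 uM as the lower. Compound 3 (`CO[C@@H]1CO[C@@H](Oc2ccc3ccccc3c2)[C@H](O)[C@H]1O`) departs from compound 2 by one change (methoxy in place of hydrogen on a saturated ring carbon), methoxy in place of hydrogen on a saturated ring carbon. Within the data shown here, the one measured step that bears on it is modest and beyond the scatter (an 8.9-fold higher number from compound 1 to compound 2 (0.95 log units; beyond the scatter)), with hydrogen in place of fluoro on that same saturated ring carbon. A lower number is therefore expected, by a smaller step (a 3.2-fold lower number from compound 2 to compound 3 (0.50 log units; beyond the scatter)). In this assay compound 3 is estimated at 90 uM (expected range 28 uM to 280 uM).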

Compound 3, concentration for half-maximal effect: 93 uM
For compound 3 the middle estimate is 1.0-fold (0.01 log units) below the measured one; the measured number falls inside the stated range.
By their numbers in this assay, from the lowest: compound 1; then compound 3; then compound 2.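

Methoxy in place of hydrogen on this saturated ring carbon gives a 3.1-fold lower number from compound 2 to compound 3 (0.49 log units; beyond the scatter) in this assay and so, like fluoro, stands on the lower side of hydrogen here. Methoxy in place of fluoro gives a 2.9-fold higher number from compound 1 to compound 3 (0.46 log units; beyond the scatter) so from the lowest number the three groups run fluoro, methoxy, hydrogen, with every step beyond the scatter. Nothing available accounts for this order. The compounds shown leave open where an amine, a chloro group or a longer chain such as ethoxy would stand at this ring carbon.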